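Cytotoxicity limits across aryl variants of the shared core

A few compounds are considered here, and "the series" means these few. Any claim that something is new, unique, unknown or untested is made for them only; others in the source may bear on it.

compound 1 (`O=[N+]([O-])c1c(CS(=O)(=O)c2ccccc2)nc2c(-c3ccccc3)cc(Cl)cn12`): > 15600 nM
compound 2 (`O=[N+]([O-])c1c(CS(=O)(=O)c2ccccc2)nc2c(-c3cccc(CO)c3)cc(Cl)cn12`): > 25000 nM
compound 3 (`O=[N+]([O-])c1c(CS(=O)(=O)c2ccccc2)nc2c(-c3ccccc3F)cc(Cl)cn12`): > 3900 nM

All three values are limits and not numbers, measured in an ADME assay on HepG2 cells (Homo sapiens) for cytotoxicity, read by MTT assay, with a stated time of 72 h; on this read-out higher numbers stand for lower toxicity in this test and lower numbers for higher toxicity in this test. Compound 3 gives only a limit (> 3900 nM). Compound 4 (`O=[N+]([O-])c1c(CS(=O)(=O)c2ccccc2)nc2c(-c3ccccc3C(F)(F)F)cc(Cl)cn12`) differs from it by trifluoromethyl in place of fluoro on an aromatic carbon (trifluoromethyl in place of fluoro on an aromatic carbon, ortho to a large group). The closest measured changes are (a step that the two limits leave unreadable from compound 1 to compound 3) and (a step that the two limits leave unreadable from compound 1 to compound 2). Neither has a readable size, so no step beyond the scatter and no direction is expected. The expected step is a step that the limit leaves unreadable from compound 3 to compound 4 in this assay. Compound 4 is estimated at 10000 nM (expected range 3900 nM to 25000 nM).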

Compound 4, half-maximal cytotoxic concentration: 22700 nM
Estimate against measurement, compound 4: 2.3-fold (0.36 log units) below; the range from low to high includes it.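

In this assay compound 4 gives 22700 nM, the first value among these aryl variants that is a number and not a limit. A 2-(trifluoromethyl)phenyl group on the shared core therefore gives this series a fixed reference point. For the compounds shown here, the only readable step is an at least 1.1-fold lower number from compound 2 to compound 4 (0.04 log units; that floor lies within the scatter), and the other steps to this compound cannot be read.

As far as these compounds go, how trifluoromethyl compares with fluoro at this place stays open. So does what an amine or a carboxylic acid in place of trifluoromethyl would give.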